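The source may hold more compounds than are shown below. What is called first, only, known or untested is meant among the compounds shown, and "the series" means these compounds.

Measured in an ADME assay on microsomes from liver (Homo sapiens) for metabolic stability; a higher number here means that the compound lasts longer, a lower number that the compound disappears faster:
- Compound 1 `NS(=O)(=O)CC(=O)NCCSc1nonc1/C(=N/O)Nc1ccc(F)c(Br)c1`: 2.37 h
- Compound 2 `CS(=N)(=O)CC(=O)NCCSc1nonc1/C(=N/O)Nc1ccc(F)c(Br)c1`: 2.65 h
- Compound 3 `NS(=O)(=O)CC(=O)NCCSc1nonc1/C(=N/O)Nc1cccc(Br)c1`: > 3 h, which is a limit of the assay

Going by the values given here, compound 2 cannot be ranked against compound 1, the only other exact number. Compound 4 `CS(=O)(=O)NCCSc1nonc1/C(=N/O)Nc1ccc(F)c(Br)c1`, not yet measured, carries methylsulfonyl on an amine nitrogen: a group of 4 heavy atoms (1 carbon, 2 oxygen, 1 sulfur; no ring) in place of a group of 7 heavy atoms (3 carbon, 1 nitrogen, 2 oxygen, 1 sulfur; no ring), on an amine nitrogen. Among the compounds with values here, the one measured step that alters the group that leaves, on a saturated chain carbon bound to a carbonyl carbon, was a 1.1-fold higher number from compound 1 to compound 2 (0.05 log units; within the scatter). The other measured step, hydrogen in place of fluoro on an aromatic carbon, was an at least 1.2-fold higher number from compound 1 to compound 3 (0.10 log units; that floor lies within the scatter). Neither replaces the whole group, so no step beyond the scatter is expected in this assay. The expected change is a 1.2-fold lower number from compound 2 to compound 4 (0.06 log units; within the scatter). For compound 4 the estimated half-life is 2.3 h, within an expected range of 1.2 h to 3 h.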

Compound 4, half-life: 1.73 h
The estimate for compound 4 lay 1.3-fold (0.12 log units) above the measured number; low and high end bracket the measured number.
By their numbers in this assay, from the lowest: compounds 4, 1 and 2 (each within the scatter of the next). At a limit, above all of these: compound 3.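

Methylsulfonyl in place of the whole group on the amine nitrogen gives a 1.5-fold lower number from compound 2 to compound 4 (0.19 log units; within the scatter) and a 1.4-fold lower number from compound 1 to compound 4 (0.14 log units; within the scatter) in this assay, so the first exchange of that entire group also stays within the scatter. At this position, the half-life does not separate methylsulfonyl from the groups it replaces. Nothing given here bears on the reason for these numbers.

On these data alone, whether a longer chain ending in an amine or a carboxylic acid would give a step beyond the scatter remains open. Compound 3 gives > 3 h, which is a limit, so its position relative to the other compounds stays unresolved.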